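The source may hold more compounds than are shown below. What is called first, only, known or untested is meant among the compounds shown, and "the series" means these compounds.

Of the compounds shown here, three have been measured in a functional assay for inhibition, with Homo sapiens as the target; a lower number here means tighter binding, a higher number weaker binding. Compound 1 `O=C(O)CC/C=C\CC1COC(c2ccc(Cl)cc2Cl)OC1c1cccnc1` gives 891 nM, and compound 2 `O=C(O)CC/C=C\CC1COC(c2ccco2)OC1c1cccnc1` gives 1260 nM; the change from compound 1 to compound 2, furan-2-yl in place of 2,4-dichlorophenyl on a saturated ring carbon, gives a 1.4-fold higher number from compound 1 to compound 2 (0.15 log units; within the scatter). Compound 3 `Cc1ccc(C#N)c(OC(C)(C)C2OCC(C/C=C\CCC(=O)O)C(c3cccnc3)O2)c1` gives 15.9 nM, the lowest of the three numbers, with its distance from both compound 1 and compound 2 well beyond the scatter.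

Compound 4 `CC(C)(C1OCC(C/C=C\CCC(=O)O)C(c2cccnc2)O1)S(=O)(=O)c1ccccc1` keeps the core of compound 3 and differs from it in one place: a group of 9 heavy atoms (6 carbon, 2 oxygen, 1 sulfur; one six-membered aromatic ring of carbon only) in place of a group of 10 heavy atoms (8 carbon, 1 nitrogen, 1 oxygen; one six-membered aromatic ring of carbon only), on a saturated chain carbon bound to two saturated chain carbons and a saturated ring carbon. Going by the values given here, no measured step bears directly on this change. Among the compounds with values here, the only measured step, from compound 1 to compound 2, stayed within the scatter, but it swaps groups on a different carbon and says little about the carbon changed here. The gap between compound 1 and compound 3 does show that what is attached at this part of the molecule can move the number a long way. Within the data shown here, with no direct precedent, a loss is expected, though a moderate one: the estimated step is a 6.3-fold higher number from compound 3 to compound 4 (0.80 log units; beyond the scatter). Compound 4 is therefore expected to give about 100 nM, with a likely range between 15 nM and 800 nM.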

Compound 4, dissociation constant: 3160 nM
Estimate against measurement, compound 4: 32-fold (1.50 log units) below; the measured number lies above the stated range.
By their numbers in this assay, from the lowest: compound 3; then compounds 1 and 2 (each within the scatter of the next); then compound 4.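

In this assay, putting phenylsulfonyl in place of the group of 10 heavy atoms on the saturated chain carbon gives a 200-fold higher number from compound 3 to compound 4 (2.30 log units; beyond the scatter), so the low number of compound 3 depends strongly on the exact group held at this carbon. The size of the step also shows that the features the two groups share are not enough to keep the number low: each has one six-membered aromatic ring of carbon only, no hydrogen-bond donors, two hydrogen-bond acceptors and no net charge, and they differ by only one heavy atom. Nothing measured here explains why the change costs so much.

This single step swaps several things at once, including the atoms joining the aromatic ring to the chain carbon and the groups on that ring, so it cannot show which of them matters. A plain phenoxy group or a phenylthio group at the same carbon would help to separate these effects, while a benzyl group would show how the number responds to a link made only of carbon.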